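The source may hold more compounds than are shown below. What is called first, only, known or untested is meant among the compounds shown, and "the series" means these compounds.

Working notes on the series. Compound 1 `c1ccc(-c2cnco2)c(NCC2=NCCN2)c1` gives 17.4 nM in a functional assay for activation of Alpha-1A adrenergic receptor (Homo sapiens), read by calcium flux (on this read-out higher numbers stand for an effect only at larger amounts of compound and lower numbers for an effect already at smaller amounts), the lowest number among the three measured. Compound 2 `Cc1cc(-c2ccccc2NCC2=NCCN2)on1` gives 38.9 nM and compound 3 `Cc1nc(-c2ccccc2NCC2=NCCN2)no1` gives 724 nM. Compound 4 `CC/C(=N\OC)c1ccccc1NCC1=NCCN1` is not yet measured. Its change from compound 1: a group of 6 heavy atoms (4 carbon, 1 nitrogen, 1 oxygen; no ring) in place of a group of 5 heavy atoms (3 carbon, 1 nitrogen, 1 oxygen; one five-membered aromatic ring with 2 hetero atoms), on an aromatic carbon. Among the measured compounds shown here, no measured step exchanges a ring for an open chain, so only the ring swaps bear on it: a 2.2-fold higher number from compound 1 to compound 2 (0.35 log units; beyond the scatter) was modest, a 42-fold higher number from compound 1 to compound 3 (1.62 log units; beyond the scatter) large, and a 19-fold higher number from compound 2 to compound 3 (1.27 log units; beyond the scatter) large in the same direction, every departure from the 1,3-oxazol-5-yl of compound 1 raising the number. A rise beyond the scatter is therefore expected for compound 4, of roughly a 4.6-fold higher number from compound 1 to compound 4 (0.66 log units; beyond the scatter). Compound 4 is estimated at 80 nM, within 20 nM to 400 nM.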

Compound 4, half-maximal effective concentration: 3.31 nM
Compound 4: middle estimate off by 24-fold (1.38 log units), on the high side; measured number below the stated range.
By their numbers in this assay, from the lowest: compound 4; then compound 1; then compound 2; then compound 3.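

At this aromatic carbon a ring is not needed for a low number: the open-chain group of compound 4, with no ring and one double bond outside aromatic rings, reverses the direction of every earlier ring swap, with a 5.3-fold lower number from compound 1 to compound 4 (0.72 log units; beyond the scatter). The size of the step depends on the group that leaves, with a 12-fold lower number from compound 2 to compound 4 (1.07 log units; beyond the scatter) and a 220-fold lower number from compound 3 to compound 4 (2.34 log units; beyond the scatter) on the same exchange of ring for open chain. No supporting data on hand bear on this reversal. As far as these compounds go, whether a carboxylic acid, a primary amide or a longer chain at this carbon would keep the low number stays open. So does the effect of the same open-chain group elsewhere on the six-membered aromatic ring.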